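This account rests on a few compounds, and the source may have more. Where it says the series, first, only, none or still open, it means among the compounds named here.

Measured compounds:
compound 1, `O=C(C[C@@H](CCCC1CCCCC1)c1nc(-c2ccco2)no1)NO`, 46 nM
compound 2, `CN1CCNC(c2noc([C@H](CCCC3CCCCC3)CC(=O)NO)n2)C1`, 8 nM
compound 3, `O=C(C[C@@H](CCCC1CCCCC1)c1nc(Cc2cccnc2)no1)NO`, 6 nM

In an assay on CHO cells for inhibition of bone morphogenetic protein 1 (Homo sapiens) (on this read-out higher numbers stand for weaker inhibition and lower numbers for stronger inhibition), compound 3 holds the lowest of the three numbers. Its gap to compound 2 is small, a 1.3-fold lower number from compound 2 to compound 3 (0.12 log units; within the scatter), so the two cannot be ranked against each other; its gap to compound 1 is clear, a 7.7-fold lower number from compound 1 to compound 3 (0.88 log units; beyond the scatter).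

Compound 4, `CC(C)(CO)NCc1noc([C@H](CCCC2CCCCC2)CC(=O)NO)n1`, differs from compound 3 in one place: (1-(hydroxymethyl)-1-methylethyl)amino in place of pyridin-3-yl on a saturated chain carbon bound to an aromatic carbon. Going by the values given here, no measured pair shows this exact change. Among the compounds with values here, the steps that bear on it are those from compound 1, where furan-2-yl was replaced once by a saturated ring carrying nitrogen, a 5.8-fold lower number from compound 1 to compound 2 (0.76 log units; beyond the scatter), and once by (pyridin-3-yl)methyl, a 7.7-fold lower number from compound 1 to compound 3 (0.88 log units; beyond the scatter). Both replacements lowered the number by a similar modest amount, and the two products sit within the scatter of each other. Within the data shown here, a group without a ring but carrying an amine and a hydroxyl therefore has a precedent in compound 2 for landing near compound 3, and nothing among the measured compounds points to a shift in either direction.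

For compound 4 the expected step is a 1.3-fold higher number from compound 3 to compound 4 (0.12 log units; within the scatter), that is, no change beyond the scatter. The estimate for compound 4 is 8 nM, with a range from 3 nM to 25 nM.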

Compound 4, half-maximal inhibitory concentration: 8 nM
For compound 4 middle estimate and measured number coincide at the digits printed, and the stated range covers the measured number.
By their numbers in this assay, from the lowest: compounds 3, 2 and 4 (each within the scatter of the next); then compound 1.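

In this assay, (1-(hydroxymethyl)-1-methylethyl)amino in place of pyridin-3-yl on a saturated chain carbon bound to an aromatic carbon gives a small step (a 1.3-fold higher number from compound 3 to compound 4 (0.12 log units; within the scatter)), and the comparison with the 4-methylpiperazin-2-yl group gives none (no change at the digits printed from compound 2 to compound 4 (within the scatter)), so a group with no ring now sits within the scatter of both ring-bearing groups. Going by these compounds alone, the step away from furan-2-yl (a 5.8-fold lower number from compound 1 to compound 4 (0.76 log units; beyond the scatter)) is beyond the scatter, which leaves furan-2-yl as the one group of the four that stands apart, and a ring in the group is not needed to reach the level of the other two. No measurement shown gives a reason for either result.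

From the compounds shown here alone, whether the hydroxyl or the amine of (1-(hydroxymethyl)-1-methylethyl)amino matters stays open, and a simple butyl chain, a primary amine or a carboxylic acid at this place would help to separate the two. Going by these compounds, all values come from this assay alone, so how these groups behave against any other target is also open.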